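Capping the Hydroxy Group: From Compound 3 to Compound 4

This account rests on a few compounds, and the source may have more. Where it says the series, first, only, none or still open, it means among the compounds named here.

Of the compounds shown here, three have been measured in an assay on isolated protein for inhibition of Amine oxidase [flavin-containing] A (Rattus norvegicus); on this read-out lower numbers stand for stronger inhibition and higher numbers for weaker inhibition. Compound 1 `CCNCc1cn(Cc2ccccc2)c2ccccc12` gives 262000 nM, compound 2 `C#CCN(Cc1ccccc1)Cc1cc2ccccc2n1C` gives 10000 nM, and compound 3 `C#CCNCc1cc2cc(O)ccc2n1C` gives 4000 nM. Compound 3 therefore stands at the lowest number of the three, and both of its gaps, to compound 2 and to compound 1, lie beyond the usual scatter, so on these numbers it is the strongest inhibitor so far.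

Compound 4 `C#CCNCc1cc2cc(OC)ccc2n1C` has not yet been measured in this assay. It is compound 3 with one change: methyl in place of hydrogen on an oxygen on an aromatic ring — hydroxy to methoxy, with one carbon entering and no ring, donor or acceptor added.

Going by the values given here, no measured pair in this set shows the same change, so nothing here tells how large a step to expect. The change is small, so the step from compound 3 to compound 4 is expected to be modest, leaning toward a weaker inhibition, as a 1.5-fold higher number from compound 3 to compound 4 (0.18 log units; within the scatter) expresses. Compound 4 is estimated at 6000 nM, within a range of 1500 nM to 25000 nM.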

Compound 4, inhibition constant: 0.8 nM
Compound 4: the middle estimate sits 7500-fold (3.88 log units) above what was measured, outside the stated range (below it).
By their numbers in this assay, from the lowest: compound 4; then compound 3; then compound 2; then compound 1.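

Methyl in place of hydrogen on an oxygen on an aromatic ring brings in this assay a 5000-fold lower number from compound 3 to compound 4 (3.70 log units; beyond the scatter) and this is a large step for a single carbon entering. Going by these compounds alone, it is the first step in this set that isolates one change, and it shows that what sits on this oxygen can by itself decide where a compound lands on this read-out. No supporting measurement bears on why the step is so large, so its cause stays unknown.

On these data alone, whether a longer chain on the same oxygen, such as ethoxy or benzyloxy, would keep the low number remains open, as does the effect of an amine or a fluorine at that place. Also open, as far as these compounds go, is whether the same methoxy group would bring a comparable step on the cores of compound 1 and compound 2.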